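A few compounds are considered here, and "the series" means these few. Any claim that something is new, unique, unknown or untested is made for them only; others in the source may bear on it.

Measured so far in a physicochemical assay for solubility, in phosphate buffer, at pH 6.5; a higher number here means a more soluble compound, a lower number a less soluble compound:
Compound 1 `C=C[C@@H]1C[C@]1(NC(=O)[C@@H]1C[C@@H](Oc2nccc3cc(OC)ccc23)CN1C(=O)[C@@H](NC(=O)N[C@H](COC)c1ccccc1)C(C)(C)C)C(=O)NS(=O)(=O)C1CC1` gives 259 ug/mL
Compound 2 `C=C[C@@H]1C[C@]1(NC(=O)[C@@H]1C[C@@H](Oc2nccc3cc(OC)ccc23)CN1C(=O)[C@@H](NC(=O)N[C@H](C(=O)OC(C)(C)C)C(C)(C)C)C(C)(C)C)C(=O)NS(=O)(=O)C1CC1` gives 1 ug/mL

Among the compounds with values here, compound 2 holds the lower of the two numbers, and the only measured step is large, with a 260-fold lower number from compound 1 to compound 2 (2.41 log units; beyond the scatter) on replacing 2-methoxy-1-phenylethyl with 2,2-dimethyl-1-(tert-butoxycarbonyl)propyl on an amide-type nitrogen. Compound 3 `C=C[C@@H]1C[C@]1(NC(=O)[C@@H]1C[C@@H](Oc2nccc3cc(OC)ccc23)CN1C(=O)[C@@H](NC(=O)N[C@H](C(=O)O)C(C)(C)C)C(C)(C)C)C(=O)NS(=O)(=O)C1CC1` departs from compound 2 in one place. The difference is hydrogen in place of tert-butyl on an oxygen next to a carbonyl group and it turns tert-butoxycarbonyl into carboxy, so that 2,2-dimethyl-1-(tert-butoxycarbonyl)propyl becomes 1-carboxy-2,2-dimethylpropyl.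

Within the data shown here, no measured step covers this exact change. Among the measured compounds shown here, the one step available touches the same substituent and shows only that the read-out can move far when that substituent is altered. On that slender basis, a large step upward is expected, recovering much of the distance to compound 1 without a firm claim of reaching it. The estimate amounts to a 150-fold higher number from compound 2 to compound 3 (2.18 log units; beyond the scatter) as the expected move in this assay for this change. For compound 3 the estimated value is 150 ug/mL with 20 ug/mL and 800 ug/mL as the expected ends of its range.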

Compound 3, solubility: > 1160 ug/mL
Compound 3 gave a limit, no number; the forecaster's own chance of this, stated with the estimate: 5%; middle value at least 7.7-fold (0.88 log units) away from the limit.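

In this assay compound 3 stands as a limit of the assay and not as a number: the limit of > 1160 ug/mL in this assay, at which 1 of the 3 values shown sits.

Hydrogen in place of tert-butyl on an oxygen next to a carbonyl group, which turns tert-butoxycarbonyl into carboxy, gives an at least 1100-fold higher number from compound 2 to compound 3 (3.06 log units; beyond the scatter), so a change confined to this one substituent moves the read-out upward as strongly as the earlier step had moved it down. Set against 2-methoxy-1-phenylethyl on the same amide-type nitrogen, 1-carboxy-2,2-dimethylpropyl gives an at least 4.4-fold higher number from compound 1 to compound 3 (0.65 log units; beyond the scatter), which shows that this substituent can do more than recover lost ground and can carry the number past the best one seen before.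

Going by these compounds, whether the rise belongs to the free carboxy group itself, or would also come with a methyl ester, a primary amide or an amine in its place, stays open. On these data alone, the actual number for compound 3 also stays open, so the full size of both steps cannot be told, and neither can what the same carboxy group would do on a substituent that keeps the phenyl ring.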